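This account rests on a few compounds, and the source may have more. Where it says the series, first, only, none or still open, it means among the compounds named here.

Measured in a functional assay on KBVIN cells (Homo sapiens) for antiproliferative activity, read by sulforhodamine B assay, with a stated time of 3 days; on this read-out higher numbers stand for an effect only at larger amounts of compound and lower numbers for an effect already at smaller amounts:
compound 1 `CCC1=C(O)c2c(oc(-c3ccc(C(C)C)cc3)cc2=O)C(CC)(CC)C1=O` gives 1.08 uM;
compound 2 `CCC1=C(O)c2c(oc(-c3ccc(O)cc3)cc2=O)C(CC)(CC)C1=O` gives 20.6 uM.

Compound 2 stands at the higher of the two numbers in this assay, the step of a 19-fold higher number from compound 1 to compound 2 (1.28 log units; beyond the scatter) lying beyond the scatter. Compound 3 `CCC1=C(O)c2c(oc(-c3ccc(SC)cc3)cc2=O)C(CC)(CC)C1=O` carries the change (methylsulfanyl in place of hydroxy on an aromatic carbon). For the measured compounds named here, the one step known, a 19-fold higher number from compound 1 to compound 2 (1.28 log units; beyond the scatter), shows the hydroxy entering and the number climbing; here the hydroxy leaves again, so a drop is expected, estimated as an 8.2-fold lower number from compound 2 to compound 3 (0.92 log units; beyond the scatter) and short of the full reversal. The entering group is not the isopropyl of compound 1. Compound 3 is expected at 2.5 uM, within 0.8 uM to 8 uM.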

Compound 3, concentration for half-maximal effect: 1.38 uM
Beside the measured number, compound 3's estimate is 1.8-fold (0.26 log units) above it; the range from low to high includes it.
By their numbers in this assay, from the lowest: compounds 1 and 3 (each within the scatter of the next); then compound 2.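

In this assay the position para to a large group is not tied to isopropyl: methylsulfanyl in place of hydroxy gives a 15-fold lower number from compound 2 to compound 3 (1.17 log units; beyond the scatter) and so recovers the loss seen with hydroxy. Methylsulfanyl and isopropyl are not told apart here, with a 1.3-fold higher number from compound 1 to compound 3 (0.11 log units; within the scatter) within the scatter, which leaves hydroxy as the only one of the three groups standing apart. Nothing at hand bears on why hydroxy differs from the other two. Open, from the compounds shown here alone, is whether methoxy, an amine or a longer chain such as ethylsulfanyl would stay with compound 1 and compound 3 or fall towards compound 2.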